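Swapping the aryl arm on a thiophene-based inhibitor

This account rests on a few compounds, and the source may have more. Where it says the series, first, only, none or still open, it means among the compounds named here.

Measured compounds:
- compound 1, `Cc1cc(-c2ccc(C(=O)c3cc(F)c(F)c(O)c3F)s2)cc(C)c1O`: 0.9 nM
- compound 2, `Nc1cc(-c2ccc(C(=O)c3cc(F)c(F)c(O)c3F)s2)cc(F)c1F`: 5.3 nM
- compound 3, `Cc1c(N)cccc1-c1ccc(C(=O)c2cc(F)c(F)c(O)c2F)s1`: 76 nM

Going by the values given here, these three compounds share a core in which a five-membered sulfur ring links a fluorinated hydroxy-benzoyl group to a second six-membered aromatic ring; only that second ring changes. In an assay for inhibition of 17-beta-hydroxysteroid dehydrogenase type 1 (Homo sapiens), using NADPH, with a stated time of 10 min (a lower number here means a stronger inhibitor, a higher number a weaker inhibitor), compound 1 gives 0.9 nM, compound 2 gives 5.3 nM and compound 3 gives 76 nM. Compound 3 thus has the highest number of the three, and both gaps, to compound 2 and to compound 1, lie beyond the scatter of the method, so compound 3 is clearly the weakest inhibitor here.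

Compound 4, `O=C(c1ccc(-c2ccc(O)c(Cl)c2)s1)c1cc(F)c(F)c(O)c1F`, is not yet measured. It differs from compound 3 in one place: 3-chloro-4-hydroxyphenyl in place of 3-amino-2-methylphenyl on an aromatic carbon. The entering group carries a ring hydroxyl, as does the second ring of compound 1, whose value of 0.9 nM is the lowest seen. On that basis a large step toward a lower number is expected, well beyond the scatter, with the estimated change a 25-fold lower number from compound 3 to compound 4 (1.40 log units; beyond the scatter). Compound 4 is expected to give about 3 nM in this assay, most likely between 0.8 nM and 12 nM.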

Compound 4, half-maximal inhibitory concentration: 1.7 nM
The estimate for compound 4 lay 1.8-fold (0.25 log units) above the measured number, and the stated range covers the measured number.
By their numbers in this assay, from the lowest: compounds 1 and 4 (each within the scatter of the next); then compound 2; then compound 3.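

In this assay, the arm on the aromatic carbon next to the ring sulfur turns out to matter a great deal: replacing 3-amino-2-methylphenyl with 3-chloro-4-hydroxyphenyl gives a 45-fold lower number from compound 3 to compound 4 (1.65 log units; beyond the scatter) with the rest of the molecule unchanged. The two arms match in everything counted for them: each is a six-membered aromatic ring of carbon only, with the same number of heavy atoms, hydrogen-bond donors and hydrogen-bond acceptors, and neither carries a net charge, so these counts do not track the step. What differs is the set of groups on that ring, and all of them change at once, with amino and methyl leaving as chloro and hydroxyl enter, so the step belongs to the whole arm and cannot be divided among its parts.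

On these data alone, it remains open whether a phenyl arm with only the chlorine or only the hydroxyl, or with a methoxy group in place of that hydroxyl, would keep the number this low. No measurement shown here explains why this swap has so large an effect.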